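Aryl swap on the propanamide side chain

The source may report more compounds than this note shows. Statements on the series, on what has been measured and on what is new or still open speak of the compounds shown alone.

The shared core is seen in compound 1 `N#Cc1c(NC(=O)C2CC2)sc2c1CCCC2`, which in a functional assay on RKE cells for antagonist activity at Vasoactive intestinal polypeptide receptor 1 (Rattus norvegicus), read by HTRF and cAMP accumulation, with stated times of 10 min and 30 min (on this read-out lower numbers stand for stronger inhibition and higher numbers for weaker inhibition), gives 2700 nM. For the measured compounds named here, compound 2 `Cc1cccc(CCC(=O)Nc2sc3c(c2C#N)CCCC3)c1` carries a 3-methylphenyl on the propanamide chain and in this assay gives 750 nM, the lowest of the two numbers so far; compound 1 stands beyond the scatter above it. Compound 3 `N#Cc1c(NC(=O)CCc2ccc(Cl)cc2)sc2c1CCCC2` is not yet measured. It differs from compound 2 by 4-chlorophenyl in place of 3-methylphenyl on a saturated chain carbon, two bonds along the chain from a carbonyl carbon. Going by the values given here, no measured pair shows this change, so its size cannot be read from the numbers at hand; with the chain and the carbonyl kept, a step within the scatter in either direction is expected. Compound 3 is expected to give 600 nM, with a range of 200 nM to 2000 nM. The expected step of a 1.3-fold lower number from compound 2 to compound 3 (0.10 log units; within the scatter) stays inside the scatter.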

Compound 3, half-maximal inhibitory concentration: 1200 nM
Beside the measured number, compound 3's estimate is 2.0-fold (0.30 log units) below it; the range from low to high includes it.
By their numbers in this assay, from the lowest: compounds 2 and 3 (each within the scatter of the next); then compound 1.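

In this assay, for the compounds shown here, the first measured pair on this aryl group gives a 1.6-fold higher number from compound 2 to compound 3 (0.20 log units; within the scatter) for 4-chlorophenyl in place of 3-methylphenyl on a saturated chain carbon, two bonds along the chain from a carbonyl carbon. At this position, then, the assay does not separate these two aryl groups, even though the pair differs in both the ring substituent and where it sits on the ring. No measurement at hand gives a reason for this step.

With both features changing together, the pair cannot show whether either one matters alone; 4-methylphenyl or 3-chlorophenyl would separate them. Going by these compounds, the effect of removing the ring substituent altogether, as in plain phenyl, or of a polar group such as an amine or a carboxylic acid on the ring, also remains open.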